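Trimethoxyphenyl series: indolyl substituent swap on the shared core

The source may hold more compounds than are shown below. What is called first, only, known or untested is meant among the compounds shown, and "the series" means these compounds.

Measured so far:
compound 1, `COc1cc(-c2ccnc3cc(-c4ccc5cc[nH]c5c4)nn23)cc(OC)c1OC`: 170 nM
compound 2, `COc1cc(-c2ccnc3c(-c4ccc(C)cc4)cnn23)cc(OC)c1OC`: > 10000 nM
compound 3, `COc1cc(-c2cc3nccc(-c4c[nH]c5ccccc45)n3n2)cc(OC)c1OC`: > 10000 nM

Going by the values given here, in a functional assay on A549 cells (Homo sapiens) for inhibition, read by CCK-8 assay, with a stated time of 48 h (a higher number here means a weaker inhibitor, a lower number a stronger inhibitor), compound 1 gives 170 nM and is the only compound with a number. For compound 2 the value > 10000 nM is a limit of this assay, not a number. For compound 3 the value > 10000 nM is likewise a limit. Compound 1 therefore stands alone as the one measurable inhibitor of the three; the other two sit at the limit described by the limit of > 10000 nM in this assay, at which 2 of the 3 values shown sit. Among the compounds with values here, no pair among the measured compounds differs in one place, so no step size is known from the data.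

Compound 4, `COc1cc(-c2ccnc3cc(-c4cn(C)c5ccccc45)nn23)cc(OC)c1OC`, is not yet measured. It differs from compound 1 by 1-methyl-1H-indol-3-yl in place of 1H-indol-6-yl on an aromatic carbon. Given the single number and the two limits, the step is expected to weaken inhibition beyond the scatter, with a real chance of another limit. The step from compound 1 to compound 4 in this assay is estimated as an 8.8-fold higher number from compound 1 to compound 4 (0.95 log units; beyond the scatter). Compound 4 is expected near 1500 nM, within 300 nM to 10000 nM.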

Compound 4, half-maximal inhibitory concentration: 1340 nM
Compound 4: the middle estimate sits 1.1-fold (0.05 log units) above what was measured; low and high end bracket the measured number.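

In this assay, going by these compounds alone, this is the first comparison between compounds that differ in one place: 1-methyl-1H-indol-3-yl in place of 1H-indol-6-yl on this aromatic carbon gives a 7.9-fold higher number from compound 1 to compound 4 (0.90 log units; beyond the scatter). The position is therefore sensitive to which indolyl group it carries, and the step now has a measured size. The change still leaves compound 4 with a number rather than a limit: the limit of > 10000 nM in this assay, at which 2 of the 4 values shown sit.

The step combines a new attachment point on the indole with a methyl group on the indole nitrogen and the loss of the hydrogen-bond donor, and these cannot be separated here. Open questions are how 1-methyl-1H-indol-6-yl would read at this carbon, and whether the indole can carry an amine or a carboxylic acid.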